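The source may hold more compounds than are shown below. What is called first, only, known or untested is meant among the compounds shown, and "the series" means these compounds.

Measured compounds in a functional assay on the whole organism (strain albino) for inhibition, with Rattus norvegicus as the target, read by paw edema, with a stated time of 1 h, at a dose of 20 mmol/kg by the intraperitoneal route; on this read-out lower numbers stand for less inhibition and higher numbers for more inhibition at the one dose given (going by the name of the read-out):
compound 1 `N#CC1=C(NCC(=O)O)N(c2ccccc2)C(=O)N2CCCCC(N3CCCC3)C12` — 67.2%
compound 2 `N#CC1=C(/N=C/Nc2ccc([N+](=O)[O-])cc2)N(c2ccccc2)C(=O)N2CCCCC(N3CCCC3)C12` — 32.1%
compound 3 `N#CC1=C(NCN2CCCCC2)N(c2ccccc2)C(=O)N2CCCCC(N3CCCC3)C12` — 29.7%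

Compound 1 stands highest of the three. The nearest to it is compound 2, with a step of a number 35.1 percentage points lower from compound 1 to compound 2 (beyond the scatter), and the furthest is compound 3, with a step of a number 37.5 percentage points lower from compound 1 to compound 3 (beyond the scatter). Between the other two the step is a number 2.4 percentage points lower from compound 2 to compound 3 (within the scatter).

Compound 4 `N#CC1=C(NC(=O)c2ccccc2O)N(c2ccccc2)C(=O)N2CCCCC(N3CCCC3)C12` has not yet been measured. It differs from compound 1 in one place: (2-hydroxyphenyl)carbonyl in place of carboxymethyl on an amine nitrogen. Both measured steps away from compound 1 also alter the carboxymethyl group of compound 1, and both were large drops. The change to compound 4 again replaces that group with something larger, so a downward step well beyond the scatter is expected here too, of about a number 29.2 percentage points lower from compound 1 to compound 4 (beyond the scatter). Compound 4 is therefore estimated to give 38% in this assay, with a likely range from 20% to 58%.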

Compound 4, a percentage reported as inhibition, in the whole organism at one dose (the size of the read-out at that dose, not a potency): 44.7%
Compound 4: the middle estimate sits 6.7 percentage points below what was measured; measured number inside the range.
By their numbers in this assay, from the lowest: compounds 3 and 2 (each within the scatter of the next); then compound 4; then compound 1.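

In this assay, the amine nitrogen does not respond to every larger group in the same way: replacing carboxymethyl with (2-hydroxyphenyl)carbonyl still gives a number 22.5 percentage points lower from compound 1 to compound 4 (beyond the scatter), yet this new group also stands clear of the two lowest compounds, with a number 15 percentage points higher from compound 3 to compound 4 (beyond the scatter) and a number 12.6 percentage points higher from compound 2 to compound 4 (beyond the scatter). Size alone therefore does not set the read-out at this position, although compound 1, the only one of the four with carboxymethyl, remains highest. Nothing available explains these differences.

From the compounds shown here alone, what remains open is whether the hydroxy group of compound 4 matters, which a plain phenylcarbonyl group on the same nitrogen would test. It is also unclear whether the lead of compound 1 depends on its carboxylic acid, which the methyl ester or a longer carboxylic acid chain would help to show.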